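A few compounds are considered here, and "the series" means these few. Any claim that something is new, unique, unknown or untested is made for them only; others in the source may bear on it.

Compound 2 `Clc1ccc2nc(-c3cccnc3)n(C3CC3)c2c1` gives 2.2 nM in an assay on V79 cells for inhibition of cytochrome P450 11B2, mitochondrial (Homo sapiens), read by HTRF, with a stated time of 1 h; on this read-out higher numbers stand for weaker inhibition and lower numbers for stronger inhibition.
Compound 1 `FC(F)(F)c1ccc2c(c1)nc(-c1cccnc1)n2C1CC1` gives > 10000 nM in this assay.

In this assay compound 2 holds the only plain number shown. For compound 1 the value is a limit rather than a number, sitting at the limit of > 10000 nM in this assay, at which 1 of the 2 values shown sits. For the measured compounds named here, because one of the two values is a limit, no step between the measured compounds can be sized, and the pair shows only that compound 2 has a firm number while compound 1 does not.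

Compound 3 `N#Cc1ccc2nc(-c3cccnc3)n(C3CC3)c2c1` is not yet measured in this assay. It differs from compound 2 in one place: cyano in place of chloro on an aromatic carbon. Chloro leaves an aromatic carbon of the six-membered aromatic ring of carbon only, part of a fused system of two rings, and cyano enters there, bringing one hydrogen-bond acceptor. Going by the values given here, no measured step here sizes such a swap, so the expectation rests on compound 2 alone. The step of a 1.8-fold higher number from compound 2 to compound 3 (0.26 log units; within the scatter) is expected to stay within the usual scatter. Compound 3 is estimated at 4 nM, with a range from 1 nM to 40 nM.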

Compound 3, half-maximal inhibitory concentration: 1.2 nM
Estimate against measurement, compound 3: 3.3-fold (0.52 log units) above; the range from low to high includes it.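

Setting cyano in place of chloro on this aromatic carbon gives a 1.8-fold lower number from compound 2 to compound 3 (0.26 log units; within the scatter) in this assay, so the two compounds cannot be told apart on this read-out. For the compounds shown here, until now, compound 2 stood alone as the only plain number, and a single value could not show whether strong inhibition required chloro at this position. Compound 3 shows that it does not: cyano, with its two heavy atoms, a triple bond and a hydrogen-bond acceptor, serves here as well as the single chlorine atom, though nothing measured here explains why these two different groups give matching results.

Two groups are a small sample of what this position might accept, and an amine, a carboxylic acid or a longer chain on the same carbon could give a very different result. Compound 1 differs from compound 2 and compound 3 in more than one place. The value of compound 1, > 10000 nM, is a limit of the assay and not a number, which leaves it unable to show what any single change does on this core.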